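A few compounds are considered here, and "the series" means these few. Any claim that something is new, unique, unknown or untested is made for them only; others in the source may bear on it.

Measured in a physicochemical assay for solubility, at pH 7.4; on this read-out lower numbers stand for lower solubility and higher numbers for higher solubility:
- compound 1 `O=C(c1cccnc1)N1CCC(NS(=O)(=O)c2cc(S(=O)(=O)c3ccccc3)ccc2C(F)(F)F)CC1`: 78000 nM
- compound 2 `O=C(C1CCNCC1)N1CCC(NS(=O)(=O)c2cc(S(=O)(=O)c3ccccc3)ccc2C(F)(F)F)CC1`: > 100000 nM, a limit
- compound 3 `O=C(CC1CCNCC1)N1CCC(NS(=O)(=O)c2cc(S(=O)(=O)c3ccccc3)ccc2C(F)(F)F)CC1`: > 100000 nM, a limit

Compound 3 has no exact number: it sits at the limit of > 100000 nM in this assay, at which 2 of the 3 values shown sit. Compound 4 `O=C([C@H]1CCNC1)N1CCC(NS(=O)(=O)c2cc(S(=O)(=O)c3ccccc3)ccc2C(F)(F)F)CC1` differs from it on the carbonyl carbon: pyrrolidin-3-yl in place of (piperidin-4-yl)methyl on a carbonyl carbon.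

Three measured steps swap the group at this same place. They are an at least 1.2-fold higher number from compound 1 to compound 2 (0.10 log units; that floor lies within the scatter), an at least 1.2-fold higher number from compound 1 to compound 3 (0.10 log units; that floor lies within the scatter) and a step that the two limits leave unreadable from compound 2 to compound 3. None of them shows a size beyond the scatter, so no real shift can be read from them. In this assay, the expected result is a number no higher from compound 3 to compound 4 (the limit leaves the size open), with no change beyond the scatter in either direction. For compound 4 the estimate is 100000 nM, with an expected range from 60000 nM to 170000 nM.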

Compound 4, solubility: 77000 nM
Compound 4: the middle estimate sits 1.3-fold (0.11 log units) above what was measured; low and high end bracket the measured number.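

Compound 4 gives an exact reading for a non-aromatic ring on this carbonyl carbon in this assay, where the two earlier such groups gave none. Its steps, an at least 1.2-fold lower number from compound 3 to compound 4 (0.11 log units; that floor lies within the scatter) and an at least 1.2-fold lower number from compound 2 to compound 4 (0.11 log units; that floor lies within the scatter), remain floors, because both starting compounds are limits: the limit of > 100000 nM in this assay, at which 2 of the 4 values shown sit. Set against pyridin-3-yl, the swap gives a 1.0-fold lower number from compound 1 to compound 4 (0.01 log units; within the scatter), so these two rings cannot be told apart here.

On these data alone, how far compound 2 and compound 3 lie past their limit stays open. So does whether an open-chain amine or a carboxylic acid on this carbonyl carbon would read differently.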